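Swapping dichlorophenyl for methoxyphenyl on a shared core

The source may hold more compounds than are shown below. What is called first, only, known or untested is meant among the compounds shown, and "the series" means these compounds.

Measured compounds in a functional assay on NCI-H1975 cells (Homo sapiens) for cytotoxicity, read by CCK-8 assay, with a stated time of 72 h; a lower number here means a stronger inhibitor, a higher number a weaker inhibitor:
compound 1 `C=CCn1c(=O)/c(=C\c2cccc(Cl)c2)[nH]c(=O)/c1=C\c1ccccc1OC`: 5100 nM
compound 2 `C=CCn1c(=O)/c(=C\c2ccccc2Cl)[nH]c(=O)/c1=C\c1ccccc1OC`: 9200 nM
compound 3 `C=CCn1c(=O)/c(=C\c2cccc(Cl)c2Cl)[nH]c(=O)/c1=C\c1ccccc1OC`: 4500 nM

Compound 3 gives the lowest of the three numbers in this assay. Its gap to compound 1 is small, since a 1.1-fold lower number from compound 1 to compound 3 (0.05 log units; within the scatter); its gap to compound 2 is larger, as a 2.0-fold lower number from compound 2 to compound 3 (0.31 log units; beyond the scatter) shows, a modest change. Between compound 1 and compound 2, a 1.8-fold higher number from compound 1 to compound 2 (0.26 log units; within the scatter).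

Compound 4 `C=CCn1c(=O)/c(=C\c2ccccc2OC)[nH]c(=O)/c1=C\c1ccccc1OC` changes the ring that carried the chlorines: 2-methoxyphenyl in place of 2,3-dichlorophenyl on a double-bonded chain carbon bound to an aromatic carbon. Among the measured compounds shown here, two measured steps bear on this. The step from compound 2 to compound 3, a 2.0-fold lower number from compound 2 to compound 3 (0.31 log units; beyond the scatter), shows that adding the second chloro brings a modest gain; the step from compound 1 to compound 2, a 1.8-fold higher number from compound 1 to compound 2 (0.26 log units; within the scatter), shows that moving a single chloro changes little. For the measured compounds named here, no measured step shows what a methoxy at this place does, so the effect of the entering group itself is unknown. Removing both chlorines is expected to give back at least the modest gain seen in compound 3, so compound 4 is expected to be a somewhat weaker inhibitor in this assay, with an expected step of a 2.2-fold higher number from compound 3 to compound 4 (0.35 log units; beyond the scatter). Compound 4 is therefore estimated at 10000 nM, within a range from 4000 nM to 25000 nM.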

Compound 4, half-maximal inhibitory concentration: 21500 nM
For compound 4 the middle estimate is 2.2-fold (0.33 log units) below the measured one, within the range that was stated.
By their numbers in this assay, from the lowest: compounds 3, 1 and 2 (each within the scatter of the next, the first and the last beyond it); then compound 4.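

In this assay the entering methoxy now has a measured effect at this place: methoxy in place of chloro, turning the 2-chlorophenyl of compound 2 into the 2-methoxyphenyl of compound 4, raises the number (a 2.3-fold higher number from compound 2 to compound 4 (0.37 log units; beyond the scatter)), so the earlier loss of a chlorine does not stand in for what this group does. The same 2-methoxyphenyl also gives a higher number when it replaces 2,3-dichlorophenyl (a 4.8-fold higher number from compound 3 to compound 4 (0.68 log units; beyond the scatter)) or 3-chlorophenyl (a 4.2-fold higher number from compound 1 to compound 4 (0.62 log units; beyond the scatter)), which makes compound 4 the weakest of the four, with all three chlorinated compounds ahead of it and none going against that order. Nothing measured here explains why the methoxy compound falls behind.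

Still open, from the compounds shown here alone, is how other groups at this place would compare with chloro and methoxy, such as a fluoro, a nitrile, an amine or a carboxylic acid, and whether a hydroxyl would behave like the methoxy. Going by these compounds, all four compounds also share one core and keep the second 2-methoxyphenyl, so it remains unknown whether these steps would hold on a different core.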